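The source may hold more compounds than are shown below. What is called first, only, known or untested is meant among the compounds shown, and "the series" means these compounds.

Measured compounds:
compound 1, `Cc1ccsc1CN[C@@H]1C[C@H]2C[C@@H]([C@H]1C)C2(C)C`: 10000 nM in an ADME assay on MDCK cells (Canis lupus familiaris) for cytotoxicity, read by microscopy, with a stated time of 48 h; on this read-out lower numbers stand for higher toxicity in this test and higher numbers for lower toxicity in this test
compound 2, `C[C@H]1[C@H](NCc2sccc2C2CCCCC2)C[C@H]2C[C@@H]1C2(C)C`: 1560 nM

Among the measured compounds shown here, compound 2 stands lowest of the two numbers in this assay, and the only measured step, a 6.4-fold lower number from compound 1 to compound 2 (0.81 log units; beyond the scatter), is the one that separates it from compound 1. Compound 3, `CCc1ccsc1CN[C@@H]1C[C@H]2C[C@@H]([C@H]1C)C2(C)C`, differs from compound 2 in one place: ethyl in place of cyclohexyl on an aromatic carbon. The change runs counter to the measured step, with ethyl standing between methyl and cyclohexyl in size, so the expectation is a number higher than that of compound 2 in this assay, probably short of the number of compound 1, since ethyl is not methyl. Compound 3 is thus expected to give 5000 nM in this assay, with a range of 2000 nM to 12000 nM. For the measured compounds named here, the expected step, a 3.2-fold higher number from compound 2 to compound 3 (0.51 log units; beyond the scatter), is a partial reversal of the one measured step, and rests on that step alone.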

Compound 3, minimum cytotoxic concentration: 25000 nM
Compound 3: the middle estimate sits 5.0-fold (0.70 log units) below what was measured, and the stated range ends below it.
By their numbers in this assay, from the lowest: compound 2; then compound 1; then compound 3.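

With a 16-fold higher number from compound 2 to compound 3 (1.20 log units; beyond the scatter), the low number in this assay stays tied to cyclohexyl at this aromatic carbon, and the size of this change exceeds that of the step from methyl to cyclohexyl. With a 2.5-fold higher number from compound 1 to compound 3 (0.40 log units; beyond the scatter), the order no longer follows group size in one direction: compound 2 fits a fall in the number as the group grows, whereas compound 3 goes against it, with ethyl giving a higher number than methyl. Nothing shown bears on the reason for this order.

Still open, from the compounds shown here alone, is whether a longer chain, such as propyl or butyl, at this place continues the rise seen with ethyl or turns towards the number of the cyclohexyl compound. Also open, going by these compounds, is where a small ring such as cyclopropyl, or a chain carrying an amine, would fall in this order.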